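From a hydroxy-bearing chain to cyanomethyl on the ring amine

A few compounds are considered here, and "the series" means these few. Any claim that something is new, unique, unknown or untested is made for them only; others in the source may bear on it.

Measured in an in vitro ADME assay on microsomes from liver (Homo sapiens) for pharmacokinetics, read by LC-MS, with a stated time of 10 min, tested at 1 uM; on this read-out higher numbers stand for fast clearance and lower numbers for slow clearance:
Compound 1 `CC(C)(C)N1C[C@H](C(=O)Nc2ccc(Cl)cc2)[C@@H](c2ccc(/C=C/C(=O)Nc3ccccc3N)cc2)C1`: 8 mL/min/kg
Compound 2 `CC(C)(CO)N1C[C@H](C(=O)Nc2ccc(Cl)cc2)[C@@H](c2ccc(/C=C/C(=O)Nc3ccccc3N)cc2)C1`: 12 mL/min/kg

Compound 2 stands at 12 mL/min/kg and cannot be told apart from compound 1 on these numbers. Compound 3 `N#CCN1C[C@H](C(=O)Nc2ccc(Cl)cc2)[C@@H](c2ccc(/C=C/C(=O)Nc3ccccc3N)cc2)C1` carries cyanomethyl in place of 1-(hydroxymethyl)-1-methylethyl on an amine nitrogen in a ring and keeps the rest of the structure. Among the measured compounds shown here, one measured step bears on this place: a 1.5-fold higher number from compound 1 to compound 2 (0.18 log units; within the scatter) when hydroxy replaced hydrogen on that chain. For the measured compounds named here, no measured compound carries cyanomethyl, so only a weak guide exists, and no step beyond the scatter is expected in this assay here. The expected step is a 1.2-fold lower number from compound 2 to compound 3 (0.08 log units; within the scatter) with wide uncertainty. Compound 3 is estimated at 10 mL/min/kg with a range from 5 mL/min/kg to 22 mL/min/kg around it.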

Compound 3, clearance: 17 mL/min/kg
Compound 3: middle estimate off by 1.7-fold (0.23 log units), on the low side; the measured number falls inside the stated range.
By their numbers in this assay, from the lowest: compounds 1, 2 and 3 (each within the scatter of the next, the first and the last beyond it).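

In this assay, cyanomethyl on the ring amine gives a 1.4-fold higher number from compound 2 to compound 3 (0.15 log units; within the scatter) and so cannot be told apart from the hydroxy-bearing chain. Set against tert-butyl, the same group gives a 2.1-fold higher number from compound 1 to compound 3 (0.33 log units; beyond the scatter) and this modest change is the first step in the series beyond the scatter, so a change at this position can shift clearance measurably. Nothing measured here gives a reason for either step.

Still open, going by these compounds, is where a plain methyl group or a longer chain ending in a carboxylic acid on this nitrogen would fall on the same read-out.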